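A few compounds are considered here, and "the series" means these few. Any claim that something is new, unique, unknown or untested is made for them only; others in the source may bear on it.

Compound 1 `Cc1ccc(NC(=O)c2ccc([N+](=O)[O-])c(OCCCCn3ccnc3)c2)cc1Nc1nccc(-c2cccnc2)n1`: 47600 nM
Compound 2 `Cc1ccc(NC(=O)c2cccc(OCCCCn3ccnc3)c2)cc1Nc1nccc(-c2cccnc2)n1`: 63400 nM

In a functional assay on K-562R cells (Homo sapiens) for cytotoxicity, read by XTT assay, with a stated time of 24 h (on this read-out lower numbers stand for stronger inhibition and higher numbers for weaker inhibition), only these two numbers exist. Compound 2, at 63400 nM, lies within the scatter of compound 1, so the pair cannot be ranked.

Compound 3 `Cc1ccc(NC(=O)c2cc(Br)cc(OCCCCn3ccnc3)c2)cc1Nc1nccc(-c2cccnc2)n1` is compound 2 with a single change: bromo in place of hydrogen on an aromatic carbon.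

Going by the values given here, one measured step bears on this, as it also exchanges a group for hydrogen on an aromatic carbon, with nitro as the group that leaves: a 1.3-fold higher number from compound 1 to compound 2 (0.12 log units; within the scatter). Among the compounds with values here, no bromo compound has been measured, so this is a loose guide. Within the data shown here, with only that small step from compound 1 to compound 2 to go on, no step beyond the scatter is expected in this assay.

The expected step is a 1.2-fold lower number from compound 2 to compound 3 (0.06 log units; within the scatter).

The estimate for compound 3 is 55000 nM, with an expected range from 28000 nM to 110000 nM.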

Compound 3, half-maximal inhibitory concentration: 19100 nM
Beside the measured number, compound 3's estimate is 2.9-fold (0.46 log units) above it, outside the stated range (below it).
By their numbers in this assay, from the lowest: compound 3; then compounds 1 and 2 (each within the scatter of the next).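

In this assay, the carbon meta to a 4-(1H-imidazol-1-yl)butoxy group proves sensitive to substitution: bromo in place of hydrogen there gives a 3.3-fold lower number from compound 2 to compound 3 (0.52 log units; beyond the scatter) and so moves the number beyond the scatter. Going by these compounds alone, the earlier exchange between nitro and hydrogen on this ring did not do so, which makes this the first change with a readable effect on cytotoxicity. No measurement here explains why the single bromine atom has this effect.

A single substituent at this carbon cannot show whether the gain is particular to bromo or would also appear with another group, such as chloro, methyl or methoxy. As far as these compounds go, it also remains open whether the same bromo step would hold with a shorter or longer chain in place of the butoxy linker.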